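The source may report more compounds than this note shows. Statements on the series, on what has been measured and on what is new or still open speak of the compounds shown alone.

Compound 1, `Nc1nn(C(=O)Nc2ccc(Cc3ccccc3)cc2)c2ccccc12`, shows in a functional assay on SK-MEL-2 cells (Homo sapiens) for antiproliferative activity, read by sulforhodamine B assay, with a stated time of 48 h (on this read-out lower numbers stand for higher toxicity in this test and higher numbers for lower toxicity in this test), no number but only a limit, > 100000 nM. Compound 2, `Nc1nn(C(=O)Nc2ccc(Cc3ccccc3)cc2)c2ccc(Cl)cc12`, shows in this assay likewise only a limit, > 100000 nM.

For the measured compounds named here, compound 2 thus stands at the ceiling of what the test reports, and the one further value shown, that of compound 1, is a limit as well; both rest at the limit of > 100000 nM in this assay, at which 2 of the 2 values shown sit. Going by the values given here, the single measured step, a step that the two limits leave unreadable from compound 1 to compound 2, cannot be read in size, both of its ends being limits.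

Compound 3, `Nc1ccc2c(c1)c(N)nn2C(=O)Nc1ccc(Cc2ccccc2)cc1`, differs from compound 2 by amino in place of chloro on an aromatic carbon; the change sits on an aromatic carbon of a six-membered carbon ring within a fused system of two rings, meta to a fused ring and para to a fused ring. Among the compounds with values here, the only measured step that touches this position, a step that the two limits leave unreadable from compound 1 to compound 2, has no readable size, so the numbers give no guide to direction. The estimate leans on both measured compounds resting at the limit, (the limit of > 100000 nM in this assay, at which 2 of the 2 values shown sit), and the step that the limit leaves unreadable from compound 2 to compound 3 is expected to be none beyond the scatter. Compound 3 is therefore estimated at 150000 nM, within 30000 nM to 1000000 nM, with a limit rather than a number the more likely outcome.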

Compound 3, concentration lethal to 50% of the cells: 90100 nM
For compound 3 the middle estimate is 1.7-fold (0.22 log units) above the measured one, within the range that was stated.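

With amino on this aromatic carbon, para to a fused ring and meta to a fused ring, compound 3 is the only one of the three compounds shown to give a number rather than a limit in this assay, 90100 nM. Measured against chloro at this place, the change gives an at least 1.1-fold lower number from compound 2 to compound 3 (0.04 log units; that floor lies within the scatter), and measured against hydrogen at the same place, it gives an at least 1.1-fold lower number from compound 1 to compound 3 (0.04 log units; that floor lies within the scatter). The position can therefore carry a readable value, but neither floor goes beyond the scatter, and the true size of either step stays unknown, since each starts from a limit: the limit of > 100000 nM in this assay, at which 2 of the 3 values shown sit.

The compounds shown leave open whether this readable value is particular to amino or would also appear with a methylamino group, an acetamido group or a hydroxyl group on the same carbon. They also leave open whether amino on another aromatic carbon of the shared core would give a number in this assay, and how far any such value would lie from the limit.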